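The compounds below may be only part of what the source reports. "The series", "measured", "known", "first", "only" and "open" are said of these compounds alone.

In an ADME assay on the whole organism (strain Sprague-Dawley) for pharmacokinetics, with Rattus norvegicus as the target, using cassette dosing, at a dose of 1 mg/kg by the oral route (on this read-out higher numbers stand for higher oral bioavailability and lower numbers for lower oral bioavailability), two compounds with the same core have been measured so far. Compound 1 (`O=C(C[C@]1(O)CC[C@@H](Cc2ccc(F)cc2)CC1)Nc1ccc2[nH]c(=O)oc2c1`) gives 42.4%, and compound 2 (`COc1ccc(C[C@H]2CC[C@](O)(CC(=O)Nc3ccc4[nH]c(=O)oc4c3)CC2)cc1`) gives 16%, the lower of the two numbers. Compound 3 (`O=C(C[C@]1(O)CC[C@@H](Cc2ccc(OC(F)(F)F)cc2)CC1)Nc1ccc2[nH]c(=O)oc2c1`) has not yet been measured. It differs from compound 2 in one place, trifluoromethyl in place of methyl on an oxygen on an aromatic ring, which turns methoxy into trifluoromethoxy.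

Within the data shown here, only one measured step bears on this change. It is a number 26.4 percentage points lower from compound 1 to compound 2 (beyond the scatter), a modest drop that came with methoxy in place of fluoro on an aromatic carbon. Compound 3 no longer carries that methoxy and, like compound 1, contains fluorine, though in a different group. Among the measured compounds shown here, a single pair is thin evidence, and no trifluoromethoxy compound has a number yet, so only a partial recovery is assumed. The expected change is a number 19 percentage points higher from compound 2 to compound 3 (beyond the scatter). For compound 3, the estimate is 35%, with an expected range of 15% to 55%.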

Compound 3, oral bioavailability: 53.4%
For compound 3 the middle estimate is 18.4 percentage points below the measured one; measured number inside the range.
By their numbers in this assay, from the lowest: compound 2; then compound 1; then compound 3.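

In this assay, replacing the methyl of the methoxy group with trifluoromethyl gives a number 37.4 percentage points higher from compound 2 to compound 3 (beyond the scatter) and counts as a large step, so the atoms attached to this oxygen on the aromatic ring matter a great deal. The earlier pair showed only that methoxy went with a lower number than fluoro, but the change from fluoro to trifluoromethoxy gives a number 11 percentage points higher from compound 1 to compound 3 (beyond the scatter) and shows that this position can also exceed the fluoro result, so an oxygen attached to the ring does not in itself bring low oral bioavailability. Nothing shown here gives a measured property that would explain either step.

As far as these compounds go, the three compounds vary only at one ring position and on one shared core, so it remains open whether a chloro group, a nitrile, or a longer chain such as ethoxy would fall nearer to methoxy or to trifluoromethoxy. From the compounds shown here alone, it is also open whether the large gain from methoxy to trifluoromethoxy would carry over to a different core, such as one with an amine or a carboxylic acid attached.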